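The compounds below may be only part of what the source reports. "The series", "measured", "known", "first", "only" and "open" are said of these compounds alone.

Measured compounds:
Compound 1 `O=C(Nc1nc(-c2cccc(OC3CCCC3)c2)cs1)c1ccc([N+](=O)[O-])o1`: 81100 nM in an ADME assay on Vero cells (Chlorocebus sabaeus) for cytotoxicity, read by MTT assay, with a stated time of 72 h; on this read-out higher numbers stand for weaker inhibition and lower numbers for stronger inhibition.
Compound 2 `O=C(Nc1nc(-c2cccc(NC(=O)C3CCC3)c2)cs1)c1ccc([N+](=O)[O-])o1`: "not determined" (no result reported) in this assay.

Compound 2 therefore stands nowhere on the numbers shown; it carries no value in this assay, and the only measured point on the shared core is compound 1, which gives 81100 nM. Compound 3 `O=C(Nc1nc(-c2cccc(NC(=O)C3CCCCC3)c2)cs1)c1ccc([N+](=O)[O-])o1` differs from compound 2 in one place: cyclohexyl in place of cyclobutyl on a carbonyl carbon. Among the compounds with values here, no step between two measured compounds exists on this core, so nothing shows how such a ring change moves this assay. Given that, the step from compound 2 to compound 3 is expected to stay within the usual scatter, in no particular direction. Taking compound 1, which gives 81100 nM, as the only anchor, compound 3 is estimated to give 80000 nM in this assay, with a range from 20000 nM to 300000 nM.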

Compound 3, half-maximal inhibitory concentration: 21900 nM
Compound 3: middle estimate off by 3.7-fold (0.56 log units), on the high side; low and high end bracket the measured number.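

In this assay the shared core now has its first readable step, a 3.7-fold lower number from compound 1 to compound 3 (0.57 log units; beyond the scatter), with (cyclohexylcarbonyl)amino in place of cyclopentyloxy on an aromatic carbon, so a change of group at this place can move the number beyond the scatter. The step from cyclobutyl to cyclohexyl on the carbonyl carbon cannot be read, for compound 2 carries no number. No measurement shown here accounts for the shift. Within the data shown here, the one readable step exchanges the linking atoms and the ring together, which leaves open whether the amide or the cyclohexyl ring matters more. As far as these compounds go, how a longer chain, an amine or a carboxylic acid in place of cyclohexyl on the carbonyl carbon would read in this assay also remains open.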